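The source may hold more compounds than are shown below. What is called first, only, known or untested is meant among the compounds shown, and "the series" means these compounds.

Compound 3 `CS(=O)(=O)Nc1cccc(-c2nc(C(c3ccc(F)cc3)c3ccc(F)cc3)sc2CC(=O)O)c1` holds the lowest number of the three measured in an in vitro assay on HEK385-7 cells for displacement of a labelled ligand from prostaglandin D2 receptor 2 (Homo sapiens); a higher number here means a weaker inhibitor, a lower number a stronger inhibitor: compound 3 gives 40 nM, whereas compound 2 `NS(=O)(=O)c1cccc(-c2nc(C(c3ccc(F)cc3)c3ccc(F)cc3)sc2CC(=O)O)c1` gives 140 nM and compound 1 `NS(=O)(=O)c1ccc(-c2nc(C(c3ccc(F)cc3)c3ccc(F)cc3)sc2CC(=O)O)cc1` gives 1500 nM. Compound 4 `O=C(O)Cc1sc(C(c2ccc(F)cc2)c2ccc(F)cc2)nc1-c1ccnc(F)c1` differs from compound 3 in one place: 2-fluoropyridin-4-yl in place of 3-(methanesulfonamido)phenyl on an aromatic carbon. All three measured steps alter this same ring: an 11-fold lower number from compound 1 to compound 2 (1.03 log units; beyond the scatter), a 38-fold lower number from compound 1 to compound 3 (1.57 log units; beyond the scatter) and a 3.5-fold lower number from compound 2 to compound 3 (0.54 log units; beyond the scatter). None of them brings in a ring with a hetero atom or removes the sulfamoyl or methanesulfonamido group entirely, so the direction rests on analogy. Since changes at this ring have each moved this assay beyond the scatter, a step beyond the scatter is expected here too, more likely towards a higher number. Compound 4 is therefore estimated at 250 nM, between 50 nM and 1200 nM, which is expected to mean a 6.3-fold higher number from compound 3 to compound 4 (0.80 log units; beyond the scatter).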

Compound 4, half-maximal inhibitory concentration: 0.48 nM
The estimate for compound 4 lay 520-fold (2.72 log units) above the measured number; measured number outside the range, below it.
By their numbers in this assay, from the lowest: compound 4; then compound 3; then compound 2; then compound 1.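

The 2-fluoropyridin-4-yl ring, on the aromatic carbon next to the ring nitrogen, gives a far lower number in this assay than any of the three benzene-ring substituents: an 83-fold lower number from compound 3 to compound 4 (1.92 log units; beyond the scatter), a 290-fold lower number from compound 2 to compound 4 (2.46 log units; beyond the scatter) and a 3100-fold lower number from compound 1 to compound 4 (3.49 log units; beyond the scatter). A low number at this position therefore does not require a sulfamoyl or methanesulfonamido group, and the entering group has fewer heavy atoms and no hydrogen-bond donor. No measurement shown accounts for the size of this gain.

As far as these compounds go, whether the ring nitrogen, the fluorine or both together matter remains open. A plain pyridin-4-yl or a 3-fluorophenyl group at this position would separate the two.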